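The source may report more compounds than this note shows. Statements on the series, on what has been measured and on what is new or still open speak of the compounds shown alone.

Measured compounds:
compound 1, `O=S(=O)(c1cc(Cl)cc(Cl)c1)c1ccc(O)nn1`, in a functional assay on the whole organism for inhibition, with Rattus norvegicus as the target, with a stated time of 60 min, at pH 4.5, at a dose of 20 mg/kg by the oral route (on this read-out higher numbers stand for a stronger effect at the one dose given and lower numbers for a weaker effect), gives 49%
compound 2, `O=S(=O)(Cc1cccc(C(F)(F)F)c1)c1ccc(O)nn1`, in this assay gives 70%

On these two numbers compound 2 holds the higher figure in this assay, and compound 1 lies lower by a gap beyond the usual scatter of repeated measurements. Among the compounds with values here, no pair that differs in only one place has yet been measured, so no step size of this series is known from the data themselves.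

The next compound, compound 3, `O=S(=O)(Cc1cccc(C(F)(F)F)c1F)c1ccc(O)nn1`, has not been measured in this assay. It differs from compound 2 in one place: fluoro in place of hydrogen on an aromatic carbon. Within the data shown here, the change is small, adding one heavy atom and no donor or acceptor, and the series offers no measured step of this kind to lean on.

Among the measured compounds shown here, with no step of this kind recorded, the step is expected to be a number 2 percentage points lower from compound 2 to compound 3 (within the scatter), that is, no change beyond the scatter. For compound 3 the estimated inhibition in this assay is 68%, with a range from 50% to 85%.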

Compound 3, a percentage reported as inhibition, in the whole organism at one dose (the size of the read-out at that dose, not a potency): 56%
For compound 3 the middle estimate is 12 percentage points above the measured one; the measured number falls inside the stated range.
By their numbers in this assay, from the lowest: compounds 1 and 3 (each within the scatter of the next); then compound 2.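

In this assay, the first single-place change measured in the series, fluoro in place of hydrogen on an aromatic carbon, gives a number 14 percentage points lower from compound 2 to compound 3 (beyond the scatter). This position on the six-membered aromatic ring of carbon only, ortho to a trifluoromethyl group, is therefore not neutral on this read-out: one added heavy atom, with no hydrogen-bond donor or acceptor, moves the number beyond the scatter, although this rests on one pair alone. Nothing at hand bears on the reason for this step.

The compounds shown leave open whether the drop belongs to fluoro itself or to this place on the ring, as they include neither a chloro, a methoxy nor an amine on this carbon, and no fluoro on another carbon of the same ring. Also open, from the compounds shown here alone, is how a longer chain joining the sulfonyl group to that ring would read, with or without the fluoro, and whether the size of the step would then hold.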